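One Thiocarbonyl Substituent Exchanged, One Number Awaited

The compounds below may be only part of what the source reports. "The series", "measured", "known", "first", "only" and "open" are said of these compounds alone.

Of the compounds shown here, three built on a shared core have been measured in a functional assay on MGC-803 cells (Homo sapiens) for inhibition, read by CCK-8 assay, with a stated time of 48 h; on this read-out lower numbers stand for stronger inhibition and higher numbers for weaker inhibition. Compound 1 (`COc1ccc(CN(C(=O)CSC(=S)N2CCN(Cc3ccc(C(C)(C)C)cc3)CC2)c2cc(OC)c(OC)c(OC)c2)cc1`) gives 5390 nM. Compound 2 (`COc1ccc(CN(C(=O)CSC(=S)N2CCOCC2)c2cc(OC)c(OC)c(OC)c2)cc1`), with morpholin-4-yl on the thiocarbonyl carbon, gives 2370 nM. Compound 3 (`COc1ccc(CN(C(=O)CSC(=S)N2CCc3ccccc32)c2cc(OC)c(OC)c(OC)c2)cc1`), with 2,3-dihydro-1H-indol-1-yl in that place, gives 8410 nM. This value lies within the scatter of the value for compound 1 but clearly apart from the value for compound 2.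

Compound 4 (`COc1ccc(CN(C(=O)CSC(=S)N2CCc3ccccc3C2)c2cc(OC)c(OC)c(OC)c2)cc1`) has not yet been measured. Its change from compound 3 is 1,2,3,4-tetrahydroisoquinolin-2-yl in place of 2,3-dihydro-1H-indol-1-yl on a thiocarbonyl carbon. Among the measured compounds shown here, only one measured step bears on this change, and only indirectly: a 3.5-fold higher number from compound 2 to compound 3 (0.55 log units; beyond the scatter). That modest step replaced morpholin-4-yl, whereas the present exchange keeps the six-membered aromatic ring of carbon only and replaces a five-membered non-aromatic ring with a six-membered one. For the measured compounds named here, no measured pair tests this exchange directly, so no step beyond the scatter is expected in this assay. The expected change is a 1.3-fold lower number from compound 3 to compound 4 (0.11 log units; within the scatter), an estimated move that remains within the scatter. For compound 4 the estimated value is 6500 nM, with an expected range from 2800 nM to 15000 nM.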

Compound 4, half-maximal inhibitory concentration: 5940 nM
For compound 4 the middle estimate is 1.1-fold (0.04 log units) above the measured one, and the stated range covers the measured number.
By their numbers in this assay, from the lowest: compound 2; then compounds 1, 4 and 3 (each within the scatter of the next).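

In this assay, the exchange of 2,3-dihydro-1H-indol-1-yl for 1,2,3,4-tetrahydroisoquinolin-2-yl on a thiocarbonyl carbon gives a 1.4-fold lower number from compound 3 to compound 4 (0.15 log units; within the scatter), so at this position the five-membered and six-membered non-aromatic rings, each carrying the same six-membered aromatic ring of carbon only, cannot be told apart. The earlier gap from morpholin-4-yl now appears with a second such group, as a 2.5-fold higher number from compound 2 to compound 4 (0.40 log units; beyond the scatter), which means that it no longer rests on 2,3-dihydro-1H-indol-1-yl alone. The data shown contain no independent measurement that would explain these values.

From the compounds shown here alone, what remains open is whether piperidin-1-yl, which keeps a six-membered non-aromatic ring but has no aromatic ring attached, would group with morpholin-4-yl or with the two groups that carry the aromatic ring. A diethylamino group on the same thiocarbonyl carbon would test the same question without any ring, and only compound 2 currently stands on the morpholin-4-yl side of the comparison.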